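Swapping the ring on the sulfonamide nitrogen of compound 2

The source may hold more compounds than are shown below. What is called first, only, known or untested is meant among the compounds shown, and "the series" means these compounds.

Compound 1, `CC(=O)Nc1c(C#N)c(-c2ccccc2)cn1-c1ccc(S(=O)(=O)Nc2ccccn2)cc1`, and compound 2, `N#Cc1c(-c2ccccc2)cn(-c2ccc(S(=O)(=O)Nc3nccs3)cc2)c1NC(=O)CCC(=O)O`, share a core and differ in two places: the acyl group on the amide nitrogen and the ring on the sulfonamide nitrogen. In a functional assay on HepG2 cells (Homo sapiens) for antiproliferative activity, read by sulforhodamine B assay, with a stated time of 48 h, tested at 40 uM (on this read-out lower numbers stand for a weaker effect and higher numbers for a stronger effect at the one concentration tested), compound 1 gives 69.9%, while compound 2 gives 49.6%, the lower of the two numbers, and that gap lies beyond the usual scatter. Compound 3, `N#Cc1c(-c2ccccc2)cn(-c2ccc(S(=O)(=O)Nc3ccccn3)cc2)c1NC(=O)CCC(=O)O`, keeps the acyl group of compound 2 and changes only the sulfonamide ring: pyridin-2-yl in place of 1,3-thiazol-2-yl on a sulfonamide nitrogen. Among the measured compounds shown here, no pair of measured compounds shows this change alone, so its effect can only be guessed. Since compound 1, which carries the pyridin-2-yl ring, shows 69.9%, a modest rise is expected, as a number 8.4 percentage points higher from compound 2 to compound 3 (within the scatter). Compound 3 is therefore estimated at 58%, with a likely range from 42% to 74%.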

Compound 3, a percentage reported as activity, at one concentration (the size of the read-out at that concentration, not a potency): 78%
Compound 3: the middle estimate sits 20 percentage points below what was measured; measured number above the stated range.
By their numbers in this assay, from the lowest: compound 2; then compounds 1 and 3 (each within the scatter of the next).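

In this assay, with the acyl group held fixed, pyridin-2-yl in place of 1,3-thiazol-2-yl on the sulfonamide nitrogen gives a number 28.4 percentage points higher from compound 2 to compound 3 (beyond the scatter). Lengthening the acyl group, with carboxymethyl in place of hydrogen on a saturated chain carbon bound to a carbonyl carbon, gives a number 8.1 percentage points higher from compound 1 to compound 3 (within the scatter), so with the pyridin-2-yl ring in place this change has no clear effect on the read-out. Nothing available explains why the ring swap matters.

The compounds shown leave open whether the acyl group would matter equally little with the 1,3-thiazol-2-yl ring in place. They also leave open how another ring on the sulfonamide nitrogen, such as pyrimidin-2-yl, would compare.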